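Swapping bromo for chloro in a permeability series

The compounds below may be only part of what the source reports. "The series", "measured", "known", "first", "only" and "open" are said of these compounds alone.

Of the compounds shown here, two have numbers so far in a physicochemical assay for permeability, using PAMPA; on this read-out higher numbers stand for higher permeability and lower numbers for lower permeability. Compound 1 `Cc1cccc(F)c1-c1nc(CN2CCC(C(=O)NCCCN3C[C@H](C)C[C@H](C)C3)CC2)c(C)o1` gives 234 10^-6 cm/s, and compound 2 `COc1cccc(Br)c1-c1nc(CN2CCC(C(=O)NCCCN3C[C@H](C)C[C@H](C)C3)CC2)c(C)o1` gives 245 10^-6 cm/s. These two values lie within the usual scatter of repeated measurements, so compound 2 cannot be ranked apart from compound 1.

The next molecule, compound 3 `COc1cccc(Cl)c1-c1nc(CN2CCC(C(=O)NCCCN3C[C@H](C)C[C@H](C)C3)CC2)c(C)o1`, differs from compound 2 in one place: chloro in place of bromo on an aromatic carbon. The rest of the molecule stays the same.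

For the measured compounds named here, only one measured step bears on this change: a 1.0-fold higher number from compound 1 to compound 2 (0.02 log units; within the scatter). In that step, 2-bromo-6-methoxyphenyl took the place of 2-fluoro-6-methylphenyl, and the result stayed within the scatter. Going by the values given here, with only that step as a guide, no shift beyond the scatter is expected in this assay, and no direction can be predicted. The expected change is small: a 1.0-fold lower number from compound 2 to compound 3 (0.01 log units; within the scatter). For compound 3, the estimated value is 238 10^-6 cm/s, with an expected range from 130 10^-6 cm/s to 430 10^-6 cm/s.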

Compound 3, apparent permeability: 51 10^-6 cm/s
Compound 3: the middle estimate sits 4.7-fold (0.67 log units) above what was measured; the measured number lies below the stated range.
By their numbers in this assay, from the lowest: compound 3; then compounds 1 and 2 (each within the scatter of the next).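

In this assay, for the compounds shown here, the group on this aromatic carbon matters more than the earlier compounds suggested: chloro in place of bromo gives a 4.8-fold lower number from compound 2 to compound 3 (0.68 log units; beyond the scatter) even though one halogen atom simply replaces another, with no ring, hydrogen-bond donor, hydrogen-bond acceptor or net charge entering or leaving. The earlier exchange of 2-fluoro-6-methylphenyl for 2-bromo-6-methoxyphenyl gave only a 1.0-fold higher number from compound 1 to compound 2 (0.02 log units; within the scatter) and stayed within the scatter, whereas 2-chloro-6-methoxyphenyl in place of the same 2-fluoro-6-methylphenyl gives a 4.6-fold lower number from compound 1 to compound 3 (0.66 log units; beyond the scatter) and lies beyond it. Among these three compounds, then, the exchange that alters one atom moves the read-out further than the exchange that alters two substituents, so the number of atoms changed does not track the size of the step.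

Nothing available here explains the drop and the compounds shown cannot say whether it belongs to chloro alone or to chloro paired with the methoxy group. Also open, from the compounds shown here alone, is how a nitrile or a trifluoromethyl group on this same carbon would read in this assay with the rest of the molecule unchanged.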